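A few compounds are considered here, and "the series" means these few. Any claim that something is new, unique, unknown or untested is made for them only; others in the source may bear on it.

Compound 1 `CN1CCC(NC(=O)c2ccc(Cn3nc(-c4cnn(C)c4)c4ccccc4c3=O)cc2)CC1` is the starting point of this account. In a functional assay on HCT-116 cells (Homo sapiens) for antiproliferative activity, read by MTT assay, with a stated time of 72 h (a higher number here means a weaker inhibitor, a lower number a stronger inhibitor), compound 1 gives 69500 nM, the highest of the two numbers that the series provides, and beyond the scatter from the nearest measured neighbour, compound 3 `Cn1cc(-c2nn(Cc3ccc(C(=O)NC4CCCC4)cc3)c(=O)c3ccccc23)cn1`, which in this assay gives 14300 nM. A third member, compound 2 `Cc1noc(C)c1-c1nn(Cc2ccc(C(=O)N3CCCCC3)cc2)c(=O)c2ccccc12`, reaches only the limit of this assay, reported as > 100000 nM; at this limit (the limit of > 100000 nM in this assay, at which 1 of the 3 values shown sits). Among the measured pairs the one step that differs in a single place is a 4.9-fold lower number from compound 1 to compound 3 (0.69 log units; beyond the scatter), a modest change that falls in the direction of a stronger inhibitor.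

The unmeasured compound 4 `Cn1cc(-c2nn(Cc3ccc(C(=O)NC4CC4)cc3)c(=O)c3ccccc23)cn1` departs from compound 1 by cyclopropyl in place of 1-methylpiperidin-4-yl on an amide-type nitrogen. The change in the step from compound 1 to compound 3 is of the same kind, a carbocycle taking the place of the 1-methylpiperidin-4-yl group, so a lowering of similar size is expected here; for compound 4 the expected step is a 3.5-fold lower number from compound 1 to compound 4 (0.54 log units; beyond the scatter), and its number in this assay is estimated at 20000 nM, within 7000 nM to 60000 nM.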

Compound 4, half-maximal inhibitory concentration: 20100 nM
The estimate for compound 4 lay 1.0-fold (0.00 log units) below the measured number; measured number inside the range.
By their numbers in this assay, from the lowest: compounds 3 and 4 (each within the scatter of the next); then compound 1. At a limit, above all of these: compound 2.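

In this assay, a second carbocycle on the amide-type nitrogen also gives a number beyond the scatter from compound 1, with a 3.5-fold lower number from compound 1 to compound 4 (0.54 log units; beyond the scatter). Cyclopropyl and cyclopentyl cannot be told apart at this position, with a 1.4-fold higher number from compound 3 to compound 4 (0.15 log units; within the scatter), so the step away from 1-methylpiperidin-4-yl now holds for two carbocycles and does not depend on which of these two is present. The measurements shown give no information on why replacing 1-methylpiperidin-4-yl changes the number. From the compounds shown here alone, whether the difference follows the ring nitrogen of 1-methylpiperidin-4-yl or the larger ring stays open, and a cyclohexyl group on the same nitrogen would separate the two. Going by these compounds, how an open chain such as n-butyl, or a piperidin-4-yl group without the methyl, would compare also remains open.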